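The source may hold more compounds than are shown below. What is called first, only, known or untested is meant among the compounds shown, and "the series" means these compounds.

Working notes on the series. All measured members share one core: compound 1 is `CC(Sc1nnc(-c2ccncc2)s1)C(=O)NCc1ccccc1`, compound 2 is `O=C(CSc1nnc(-c2ccncc2)s1)NCc1ccc(Cl)cc1` and compound 3 is `O=C(CSc1nnc(-c2ccncc2)s1)Nc1ccc(Cl)cc1`. In an ADME assay on BHK-21 cells (Mesocricetus auratus) for cytotoxicity, with a stated time of 3 days (on this read-out higher numbers stand for lower toxicity in this test and lower numbers for higher toxicity in this test), compound 1 gives > 50000 nM, which is a limit of the assay rather than a number. Compound 2 likewise gives only a limit, > 50000 nM. Compound 3 also stops at a limit with > 50000 nM, so where it stands can only be described as at or beyond that limit, the same place as the two other members. Going by the values given here, the one single-place step among the measured compounds, a step that the two limits leave unreadable from compound 2 to compound 3, is unreadable because both ends sit at the limit of > 50000 nM in this assay, at which 3 of the 3 values shown sit.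

Compound 4 is `O=C(CSc1nnc(-c2ccncc2)s1)NCc1ccccc1`. It differs from compound 3 by benzyl in place of 4-chlorophenyl on an amide-type nitrogen. Among the compounds with values here, the step from compound 2 to compound 3 is the only one that touches the same nitrogen, and it gives no size, so no measured step reads on this change. With every value shown resting at the limit, no step beyond the scatter is expected: the expected step is a step that the limit leaves unreadable from compound 3 to compound 4. Compound 4 is estimated at 60000 nM, within 30000 nM to 200000 nM, most likely again reported only as a limit.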

Compound 4, half-maximal cytotoxic concentration: 11300 nM
For compound 4 the middle estimate is 5.3-fold (0.73 log units) above the measured one; measured number below the stated range.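

Benzyl in place of 4-chlorophenyl on the amide-type nitrogen gives an at least 4.4-fold lower number from compound 3 to compound 4 (0.64 log units; beyond the scatter). Hydrogen in place of chloro on an aromatic carbon gives an at least 4.4-fold lower number from compound 2 to compound 4 (0.64 log units; beyond the scatter), and hydrogen in place of methyl on the saturated chain carbon bound to a carbonyl carbon and a sulfur gives an at least 4.4-fold lower number from compound 1 to compound 4 (0.64 log units; beyond the scatter), so toxicity in this assay first becomes readable in this series with compound 4, and all three single-place changes into it lead to a lower number. The true sizes of these steps stay unknown because the other compounds rest at a limit: the limit of > 50000 nM in this assay, at which 3 of the 4 values shown sit.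

The step between the two limits, from compound 2 to compound 3, still cannot be read. From the compounds shown here alone, it remains open how a longer chain or an amine in place of benzyl on the amide-type nitrogen would read out in this assay.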